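Pyrazin-2-yl for Pyridin-4-yl on the Amine Nitrogen of Compound 1

The compounds below may be only part of what the source reports. "The series", "measured", "known", "first", "only" and "open" are said of these compounds alone.

Measured compounds:
compound 1 `O=C(c1nc2ccccc2s1)N1CCN(c2ccncc2)CC1`: 62%
compound 2 `O=C(c1nc2cc(C(F)(F)F)ccc2s1)N1CCN(c2ccncc2)CC1`: 17.5%

In an ADME assay on RAW264.7 cells (Mus musculus) for cytotoxicity, read by MTT assay, with a stated time of 72 h, tested at 50 ug/mL (on this read-out higher numbers stand for more inhibition at the one concentration tested (going by the name of the read-out) and lower numbers for less inhibition), compound 1 gives 62%, the highest of the two numbers shown. Compound 2 gives 17.5% in this assay. Within the data shown here, the single measured step, a number 44.5 percentage points lower from compound 1 to compound 2 (beyond the scatter), is trifluoromethyl in place of hydrogen on an aromatic carbon, and it lies beyond the scatter.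

Compound 3 `O=C(c1nc2ccccc2s1)N1CCN(c2cnccn2)CC1` is the next compound to be measured. It differs from compound 1 in one place: pyrazin-2-yl in place of pyridin-4-yl on an amine nitrogen in a ring. The measured step from compound 1 to compound 2 changes a different part of the shared core, so it does not bear directly on this change; the two values only show that a single substituent can move the read-out a long way. Among the measured compounds shown here, no measured step speaks to the exchange of one six-membered aromatic ring for another on the amine nitrogen in a ring, so the direction is open. Compound 3 is expected to give a number close to that of compound 1, with a step estimated as a number 10 percentage points lower from compound 1 to compound 3 (within the scatter), most likely within the scatter. The estimate for compound 3 in this assay is 52%, with a range from 28% to 74%.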

Compound 3, a percentage reported as inhibition, at one concentration (the size of the read-out at that concentration, not a potency): 65.3%
Beside the measured number, compound 3's estimate is 13.3 percentage points below it; measured number inside the range.
By their numbers in this assay, from the lowest: compound 2; then compounds 1 and 3 (each within the scatter of the next).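

In this assay, among these compounds, pyrazin-2-yl in place of pyridin-4-yl on the amine nitrogen in a ring amounts to a number 3.3 percentage points higher from compound 1 to compound 3 (within the scatter), the first reading of any change at this position. Among the compounds shown here, the entering ring holds 2 hetero atoms and 2 hydrogen-bond acceptors where the leaving ring holds 1 of each, and at the one concentration tested this exchange does not separate compound 3 from compound 1, whereas the trifluoromethyl change elsewhere on the shared core amounts to a number 44.5 percentage points lower from compound 1 to compound 2 (beyond the scatter). No independent measurement is available to account for this result.

Going by these compounds, whether this position stays as unresponsive with a group further from these two rings, such as a plain phenyl ring, a morpholine or a short alkyl chain on the amine nitrogen, remains open, since one exchange between two six-membered aromatic rings cannot describe the whole position. On these data alone, it is also open whether trifluoromethyl on the core of compound 3 would bring a drop in the read-out of the kind seen with compound 2, or whether a different outcome would follow with the pyrazin-2-yl group in place.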